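Thioether for ether on the shared core

This account rests on a few compounds, and the source may have more. Where it says the series, first, only, none or still open, it means among the compounds named here.

Compound 1 `COc1ccc(Sc2nc3cc(N)cc(N)c3nc2-c2ccccc2)cc1` in a functional assay on MOLT-4 cells (Homo sapiens) for inhibition, read by sulforhodamine B assay, with a stated time of 48 h (on this read-out higher numbers stand for weaker inhibition of growth and lower numbers for stronger inhibition of growth), gives < 100000 nM, a limit of the assay.
Compound 2 `Nc1cc(N)c2nc(-c3ccccc3)c(Oc3ccc(F)cc3)nc2c1` in this assay gives < 100000 nM, a limit of the assay.

Compound 2 therefore stands only at a limit of this assay; the limit of < 100000 nM in this assay, at which 2 of the 2 values shown sit, describes the whole measured set. Compound 3 `Nc1cc(N)c2nc(-c3ccccc3)c(Sc3ccc(F)cc3)nc2c1` differs from compound 2 by (4-fluorophenyl)sulfanyl in place of 4-fluorophenoxy on an aromatic carbon. Within the data shown here, the single measured step, a step that the two limits leave unreadable from compound 1 to compound 2, cannot be read. Compound 1 also carries a sulfanyl link and also sits at the limit, so the measured steps give no direction. The expected step is a step that the limit leaves unreadable from compound 2 to compound 3. Compound 3 is estimated at 20000 nM, with a range from 2000 nM to 90000 nM, and a fair chance that only a limit is reported again.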

Compound 3, concentration for total growth inhibition: < 100000 nM
Compound 3 gave a limit, no number; the forecaster's own chance of this, stated with the estimate: 50%; the middle value is on the limit's open side.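

Compound 1, compound 2 and compound 3 all sit at a limit of this assay, so no step among them can be read: the limit of < 100000 nM in this assay, at which 3 of the 3 values shown sit.

The compounds shown leave open whether (4-fluorophenyl)sulfanyl and 4-fluorophenoxy differ at all on the shared core in this assay.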